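Chloro for Nitro: An Expected Shift in Cytotoxicity

The source may hold more compounds than are shown below. What is called first, only, known or untested is meant among the compounds shown, and "the series" means these compounds.

Compound 2, `COc1cc(C2=CC(c3ccc([N+](=O)[O-])cc3)NC(=S)N2)cc(OC)c1OC`, in a functional assay on L1210 cells (Mus musculus) for cytotoxicity, read by MTT assay, with a stated time of 72 h (on this read-out lower numbers stand for stronger inhibition and higher numbers for weaker inhibition), gives only a limit, > 100000 nM. Compound 1, `COc1ccc(C2C=C(c3cc(OC)c(OC)c(OC)c3)NC(=S)N2)cc1O`, gives 500 nM in this assay, and the step of an at least 200-fold higher number from compound 1 to compound 2 (2.30 log units; beyond the scatter) separates the two; the shared core is carried into compound 3, `COc1cc(C2=CC(c3ccc(Cl)cc3)NC(=S)N2)cc(OC)c1OC`. The change from compound 2 to compound 3 is chloro in place of nitro on an aromatic carbon. Among the measured compounds shown here, no measured step touches that position: the only step known, an at least 200-fold higher number from compound 1 to compound 2 (2.30 log units; beyond the scatter), concerns the aryl group on the saturated ring carbon, so it offers neither a size nor a direction for the present change. Compound 2 sits at the limit of > 100000 nM in this assay, at which 1 of the 2 values shown sits, so any number for compound 3 can only be read as starting from there. Lacking a comparable step, compound 3 is expected to stay weak, estimated at about 50000 nM, between 5000 nM and 200000 nM, with the expected step of an at least 2.0-fold lower number from compound 2 to compound 3 (0.30 log units; that floor lies within the scatter) carrying wide uncertainty.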

Compound 3, half-maximal inhibitory concentration: 48300 nM
Compound 3: middle estimate off by 1.0-fold (0.02 log units), on the high side; low and high end bracket the measured number.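

In this assay, among the compounds shown here, the aromatic carbon carrying the nitro group proves to be a place where a change can be read: chloro in place of nitro gives an at least 2.0-fold lower number from compound 2 to compound 3 (0.31 log units; beyond the scatter) and so supplies the first measured step here, with a direction and a floor for its size. The other step, a 97-fold higher number from compound 1 to compound 3 (1.98 log units; beyond the scatter), concerns the aryl group on the saturated ring carbon and is large. Chloro at this place therefore does not bring the number back to the level set by the 3-hydroxy-4-methoxyphenyl group.

From the compounds shown here alone, whether an amine or a carboxylic acid on this aromatic carbon would move the number further remains open. The true size of the step from nitro to chloro also stays open, because compound 2 gives only a limit and not a number: the limit of > 100000 nM in this assay, at which 1 of the 3 values shown sits.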